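A Benzyl Group Enters at a Saturated Chain Carbon

The source may hold more compounds than are shown below. What is called first, only, known or untested is meant among the compounds shown, and "the series" means these compounds.

Measured compounds:
- compound 1, `O=C(O)CC/C=C\CC1COC(c2ccc(Cl)cc2Cl)OC1c1cccnc1`: 891 nM
- compound 2, `Cc1ccc(C#N)c(OC(C)(C)C2OCC(C/C=C\CCC(=O)O)C(c3cccnc3)O2)c1`: 15.9 nM
- compound 3, `COc1ccc(SC(C)(C)C2OCC(C/C=C\CCC(=O)O)C(c3cccnc3)O2)c([N+](=O)[O-])c1`: 158 nM

The measurements come from a functional assay for inhibition, with Homo sapiens as the target; on this read-out higher numbers stand for weaker binding and lower numbers for tighter binding. On that read-out compound 2 gives 15.9 nM, the lowest of the three numbers. Its nearest neighbour is compound 3, which gives 158 nM, a gap beyond the usual scatter. Compound 1 lies furthest away and gives 891 nM, again well beyond the scatter. Compound 2 is therefore the tightest binder among the three.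

The new compound is compound 4, `CC(C)(Cc1ccccc1)C1OCC(C/C=C\CCC(=O)O)C(c2cccnc2)O1`. It differs from compound 2 in one place:
a group of 7 heavy atoms (7 carbon; one six-membered aromatic ring of carbon only) in place of a group of 10 heavy atoms (8 carbon, 1 nitrogen, 1 oxygen; one six-membered aromatic ring of carbon only), on a saturated chain carbon bound to two saturated chain carbons and a saturated ring carbon

For the measured compounds named here, no pair of measured compounds differs in just one place, so there is no directly comparable step to lean on. The three measured values show that the group attached at this chain carbon matters a great deal, and that the group in compound 2, with its two hydrogen-bond acceptors, goes with the lowest number. Losing both acceptors and three heavy atoms is expected to cost binding: the step of a 6.3-fold higher number from compound 2 to compound 4 (0.80 log units; beyond the scatter) is estimated to run upward, beyond the scatter but short of the distance to compound 1. Compound 4 is therefore expected to give about 100 nM, with a plausible range from 25 nM to 400 nM.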

Compound 4, dissociation constant: 513 nM
Estimate against measurement, compound 4: 5.1-fold (0.71 log units) below; the measured number lies above the stated range.
By their numbers in this assay, from the lowest: compound 2; then compound 3; then compounds 4 and 1 (each within the scatter of the next).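

In this assay, the change at this saturated chain carbon brings a 32-fold higher number from compound 2 to compound 4 (1.51 log units; beyond the scatter), even though the entering benzyl group keeps a six-membered aromatic ring of carbon only. An aromatic ring at this carbon is therefore not enough to hold the low number of compound 2, and the rest of the leaving group, with its nitrogen, its oxygen and its triple bond, goes with a large part of the difference. At the saturated ring carbon, 1-benzyl-1-methylethyl in place of 2,4-dichlorophenyl gives a 1.7-fold lower number from compound 1 to compound 4 (0.24 log units; within the scatter), so these two groups cannot be told apart on this read-out, and nothing available explains either step.

Because the leaving and entering groups differ in several features at once, the compounds shown leave open which feature of the leaving group accounts for the large step. They also leave open whether an amine or a carboxylic acid on the aromatic ring of the benzyl group would bring the number of compound 4 back towards that of compound 2.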